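Trifluoromethyl for Fluoro on a Scaffold at the Limit

The source may report more compounds than this note shows. Statements on the series, on what has been measured and on what is new or still open speak of the compounds shown alone.

Compound 1 `C/C(=C\c1cc(-c2cccnc2)co1)C(N)=O` and compound 2 `C/C(=C\c1cc(-c2ccc(F)cc2)cs1)C(N)=O` were both tested in a functional assay on BGC-823 cells (Homo sapiens) for cytotoxicity, read by CCK-8 assay, with a stated time of 24 h; a higher number here means a weaker inhibitor, a lower number a stronger inhibitor. In this assay compound 1 gives only a limit, > 50000 nM. Compound 2 likewise reaches only a limit in this assay, > 50000 nM, so compound 2 stands at the limit of > 50000 nM in this assay, at which 2 of the 2 values shown sit, together with every value shown. Compound 3 `C/C(=C\c1cc(-c2ccc(C(F)(F)F)cc2)cs1)C(N)=O` carries trifluoromethyl in place of fluoro on an aromatic carbon, the trifluoromethyl set para to a large group. Among the compounds with values here, with no measured step to lean on, compound 3 is expected to sit where compound 2 does, any change no larger than the scatter and most likely again a limit. The expected step is a number no higher from compound 2 to compound 3 (the limit leaves the size open). Compound 3 is estimated at 50000 nM, within 15000 nM to 200000 nM.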

Compound 3, half-maximal inhibitory concentration: > 50000 nM
Compound 3 was reported as a limit (the forecaster's own chance of this, stated with the estimate: 80%); the middle value sits exactly at the limit.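

In this assay compound 3 gives only a limit, > 50000 nM. Compound 2 is also a limit, so no step can be read between compound 2 and compound 3. The compounds shown leave open how far past the limit each one's true value lies.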